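Replacing methyl on an amide-type nitrogen of compound 3

The compounds below may be only part of what the source reports. "The series", "measured", "known", "first", "only" and "open" are said of these compounds alone.

Going by these compounds, in a physicochemical assay for solubility (a lower number here means a less soluble compound, a higher number a more soluble compound), compound 3 `CNC(=O)c1cc(C(=O)NC)n([C@@H](C)c2ccccc2)n1` gives >= 88 ug/mL as a limit, not a number, so its true place stays open. Compound 1 `CNC(=O)c1cc(C(=O)NCCO)n([C@@H](C)c2ccccc2)n1` gives >= 139 ug/mL as a limit too. Compound 2 `CNC(=O)c1cc(C(=O)N[C@H]2CC[C@H](OC)CC2)n([C@@H](C)c2ccccc2)n1` likewise gives >= 161 ug/mL as a limit. Compound 4 `CNC(=O)c1cc(C(=O)NC(C)CO)n([C@@H](C)c2ccccc2)n1` carries 1-(hydroxymethyl)ethyl in place of methyl on an amide-type nitrogen. Measured steps bear on this change in a step that the two limits leave unreadable from compound 1 to compound 3 and in a step that the two limits leave unreadable from compound 2 to compound 3 but neither gives a size. They offer no direction in this assay either, so no change beyond the scatter is expected, the estimated step being a step that the limit leaves unreadable from compound 3 to compound 4 in size. Compound 4 is estimated at 135 ug/mL with an expected range from 80 ug/mL to 220 ug/mL.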

Compound 4, solubility: >= 132 ug/mL
Compound 4 ended at the assay's limit; the forecaster's own chance of this, stated with the estimate: 75%; the middle value does not contradict the limit.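

Among these compounds, compound 4, like compounds 1, 2 and 3, gives only a limit, so no step between any of them can be read. The compounds shown leave open how far each true solubility lies past its limit, and whether 1-(hydroxymethyl)ethyl in place of methyl changes it at all.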